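Working notes: 2-chlorobenzyl to 3,4-dichlorobenzyl

The source may hold more compounds than are shown below. What is called first, only, known or untested is meant among the compounds shown, and "the series" means these compounds.

- Compound 1 `CCN(CC)Cc1ccc2nc(NC(=O)N/N=C/c3cn(Cc4ccc(Cl)cc4Cl)c4ccccc34)sc2c1` in a functional assay on MDA-MB-231 cells (Homo sapiens) for cytotoxicity, read by MTT assay, with a stated time of 72 h (a higher number here means a weaker inhibitor, a lower number a stronger inhibitor), gives 3280 nM
- Compound 2 `CCN(CC)Cc1ccc2nc(NC(=O)N/N=C/c3cn(Cc4ccccc4Cl)c4ccccc34)sc2c1` in this assay gives 900 nM

Among the measured compounds shown here, compound 2 holds the lower of the two numbers measured so far. Compound 3 `CCN(CC)Cc1ccc2nc(NC(=O)N/N=C/c3cn(Cc4ccc(Cl)c(Cl)c4)c4ccccc34)sc2c1` differs from it as follows: 3,4-dichlorophenyl in place of 2-chlorophenyl on a saturated chain carbon bound to an aromatic nitrogen. For the measured compounds named here, one measured step bears on this change, a 3.6-fold lower number from compound 1 to compound 2 (0.56 log units; beyond the scatter), where hydrogen replaces chloro on an aromatic carbon. Compound 3 also gains a chlorine, so a modest step toward a higher number is expected in this assay. Going by the values given here, no measured step covers the 3,4-dichlorophenyl group itself, so the range stays wide. The expected change is a 2.2-fold higher number from compound 2 to compound 3 (0.35 log units; beyond the scatter). Compound 3 is estimated at 2000 nM, with an expected range of 700 nM to 5500 nM.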

Compound 3, half-maximal inhibitory concentration: 4490 nM
Beside the measured number, compound 3's estimate is 2.2-fold (0.35 log units) below it; measured number inside the range.
By their numbers in this assay, from the lowest: compound 2; then compounds 1 and 3 (each within the scatter of the next).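

Both dichlorophenyl groups on this saturated chain carbon now sit above the 2-chlorophenyl group, and the change to 3,4-dichlorophenyl gives a 5.0-fold higher number from compound 2 to compound 3 (0.70 log units; beyond the scatter). The two dichloro arrangements are not separated, with 3,4-dichlorophenyl in place of 2,4-dichlorophenyl giving a 1.4-fold higher number from compound 1 to compound 3 (0.14 log units; within the scatter). No evidence on why the second chlorine raises the number is available.

Still open, from the compounds shown here alone, is whether a ring with a single fluoro or methoxy group, or an unsubstituted benzyl, holds the number of compound 2. The three compounds also leave open whether a single chlorine at the 3- or 4-position would do the same.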